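Trifluoromethylphenyl to Sulfamoylphenyl on a Shared Core

A few compounds are considered here, and "the series" means these few. Any claim that something is new, unique, unknown or untested is made for them only; others in the source may bear on it.

Compound 2 `CCCS(=O)(=O)Nc1ccc(F)c(C(=O)c2n[nH]c3ncc(-c4ccc(C(F)(F)F)cc4)cc23)c1F` gives 29% in an assay for binding affinity to dual specificity mitogen-activated protein kinase kinase 4 (Homo sapiens), read by KINOMEscan, tested at 100 nM (a higher number here means a weaker effect of the compound at the concentration tested, a lower number a stronger effect), the highest of the two numbers recorded so far; its nearest neighbour, compound 1 `CCCS(=O)(=O)Nc1ccc(F)c(C(=O)c2n[nH]c3ncc(-c4ccc(C)c(C)c4)cc23)c1F`, gives 20% in this assay. For the measured compounds named here, the only step between measured compounds, a number 9 percentage points higher from compound 1 to compound 2 (within the scatter), lies within the scatter. Compound 3 `CCCS(=O)(=O)Nc1ccc(F)c(C(=O)c2n[nH]c3ncc(-c4ccc(S(N)(=O)=O)cc4C)cc23)c1F` carries 2-methyl-4-sulfamoylphenyl in place of 4-(trifluoromethyl)phenyl on an aromatic carbon. That single earlier step bears on this change only loosely, and it was small, so no shift beyond the scatter is expected here either. Compound 3 is therefore estimated at 25% in this assay, between 8% and 55%, which means an expected step of a number 4 percentage points lower from compound 2 to compound 3 (within the scatter).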

Compound 3, a percentage reported as activity, at one concentration (the size of the read-out at that concentration, not a potency): 3.1%
Estimate against measurement, compound 3: 21.9 percentage points above, and the stated range ends above it.
By their numbers in this assay, from the lowest: compound 3; then compounds 1 and 2 (each within the scatter of the next).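

In this assay, this position on the shared core now shows a change beyond the scatter: 2-methyl-4-sulfamoylphenyl gives a number 25.9 percentage points lower from compound 2 to compound 3 (beyond the scatter), and set against 3,4-dimethylphenyl it gives a number 16.9 percentage points lower from compound 1 to compound 3 (beyond the scatter). For the compounds shown here, the earlier exchange of aryl groups here stayed within the scatter, so compound 3 is the first to stand apart from the others. Nothing available explains this shift.

The entering group differs in both its methyl and its sulfamoyl, and the compounds shown do not separate the two. On these data alone, whether 4-sulfamoylphenyl alone, or a phenyl carrying a carboxylic acid or an amine instead of the sulfamoyl, would give a similar read-out stays open.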